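The source may report more compounds than this note shows. Statements on the series, on what has been measured and on what is new or still open speak of the compounds shown alone.

Measured compounds in a toxicity assay on L02 cells (Homo sapiens) for cytotoxicity, read by CCK-8 assay, with a stated time of 72 h; on this read-out higher numbers stand for weaker inhibition and lower numbers for stronger inhibition:
- compound 1 `CC(C)(C)OC(=O)/C=C1/C(=O)Nc2ccccc21`, 2450 nM
- compound 2 `CC(C)(C)OC(=O)/C=C1/C(=O)N(Cc2ccccc2)c2ccccc21`, 5030 nM
- compound 3 `CN1C(=O)/C(=C/C(=O)OC(C)(C)C)c2ccccc21`, 4320 nM

Compound 3 stands second highest of the three numbers in this assay. Its nearest neighbour is compound 2, a 1.2-fold lower number from compound 2 to compound 3 (0.07 log units; within the scatter), and its furthest is compound 1, a 1.8-fold higher number from compound 1 to compound 3 (0.25 log units; within the scatter); neither separation is beyond the scatter, so on these numbers compound 3 cannot be told apart from the others. Among the compounds with values here, the one step that does clear the scatter, a 2.1-fold higher number from compound 1 to compound 2 (0.31 log units; beyond the scatter), is modest.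

Compound 4 `CN1C(=O)/C(=C/C(=O)Oc2ccccc2)c2ccccc21` differs from compound 3 in one place: phenyl in place of tert-butyl on an oxygen next to a carbonyl group. Within the data shown here, all three measured steps are on the amide-type nitrogen in the ring; none touches the oxygen next to the carbonyl group, so the series gives no direct precedent for this change. The measured steps together span only a small range, which argues for a small step here as well, with no preferred direction.

The expectation for compound 4 is therefore a 1.1-fold lower number from compound 3 to compound 4 (0.03 log units; within the scatter), no step beyond the scatter. Compound 4 is estimated at 4000 nM in this assay, with a range of 1500 nM to 11000 nM.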

Compound 4, half-maximal inhibitory concentration: 22700 nM
Beside the measured number, compound 4's estimate is 5.7-fold (0.75 log units) below it; the whole stated range lies below it.
By their numbers in this assay, from the lowest: compounds 1, 3 and 2 (each within the scatter of the next, the first and the last beyond it); then compound 4.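

In this assay phenyl in place of tert-butyl gives a 5.3-fold higher number from compound 3 to compound 4 (0.72 log units; beyond the scatter) and so moves the read-out toward weaker inhibition, which marks the group on the oxygen next to a carbonyl group as a place where this cytotoxicity read-out responds to a change. Within the data shown here, until now the only information came from the amide-type nitrogen in the ring, where benzyl in place of hydrogen gave a 2.1-fold higher number from compound 1 to compound 2 (0.31 log units; beyond the scatter) and methyl in place of hydrogen gave a 1.8-fold higher number from compound 1 to compound 3 (0.25 log units; within the scatter) and the series said nothing about the other end of the molecule. Nothing available explains why phenyl and tert-butyl part here, and this single pair supports no reason for the step.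

On these data alone, with only tert-butyl and phenyl on this oxygen, it remains open whether a small group such as methyl, a longer chain or a benzyl group would read like compound 3 or like compound 4. As far as these compounds go, it is also open whether the same change keeps its size and direction when the amide-type nitrogen carries hydrogen or benzyl instead of methyl.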